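The source may report more compounds than this note shows. Statements on the series, on what has been measured and on what is new or still open speak of the compounds shown alone.

Of the compounds shown here, three with the same core have so far been tested in a functional assay on the whole organism with Mus musculus as the target; on this read-out lower numbers stand for an effect already at smaller amounts and higher numbers for an effect only at larger amounts of compound. Compound 1 `C/C(C(=O)NC1CC1)=C(/C)c1cccc(C(F)(F)F)c1` carries a cyclopropyl group on its amide nitrogen and gives 17.4 mg/kg. Compound 2 `C#CCNC(=O)/C(C)=C(\C)c1cccc(C(F)(F)F)c1` carries a propargyl group in that position instead, and in this assay compound 2 gives 25.1 mg/kg. Swapping one for the other made only a small difference: a 1.4-fold higher number from compound 1 to compound 2 (0.16 log units; within the scatter). Compound 3 `C/C(=C\c1cccc(C(F)(F)F)c1)C(N)=O` is the simplest of the three, with an unsubstituted amide, and in this assay compound 3 gives 22.4 mg/kg, a number that lies between those of compound 1 and compound 2 and within the scatter of both.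

Compound 4 `C/C(=C\c1cccc(C(F)(F)F)c1)C(=O)NC1CC1` is the next step from compound 3. The change is cyclopropyl in place of hydrogen on an amide-type nitrogen. Going by the values given here, no measured step shows exactly this change from a bare amide hydrogen to a cyclopropyl group. Among the compounds with values here, the only step that touches the same position is the one from compound 1 to compound 2, which stayed within the scatter, and the values of compound 1 and compound 3 also sit within the scatter of each other. On that basis the step is expected to be small: a 1.1-fold lower number from compound 3 to compound 4 (0.05 log units; within the scatter). Compound 4 is therefore estimated to give 20 mg/kg in this assay, somewhere between 10 mg/kg and 40 mg/kg.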

Compound 4, dose for half-maximal effect: 24.1 mg/kg
Compound 4: middle estimate off by 1.2-fold (0.08 log units), on the low side; the range from low to high includes it.
By their numbers in this assay, from the lowest: compounds 1, 3, 4 and 2 (each within the scatter of the next).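

In this assay, going by these compounds alone, cyclopropyl in place of hydrogen on the amide-type nitrogen gives a 1.1-fold higher number from compound 3 to compound 4 (0.03 log units; within the scatter), and this is the first direct comparison of the bare amide hydrogen with a group on that nitrogen. Adding a ring of 3 carbon atoms at this position therefore leaves the read-out within the scatter, so this measurement cannot tell the cyclopropyl amide from the unsubstituted amide, just as the earlier swap of cyclopropyl for propargyl, a 1.4-fold higher number from compound 1 to compound 2 (0.16 log units; within the scatter), could not tell those two groups apart. No measurement shown here explains why the change in this position has so little visible effect.

As far as these compounds go, the amide-type nitrogen is seen here with only hydrogen, cyclopropyl and propargyl, so it remains open whether a longer chain such as n-hexyl, or a chain ending in an amine, would also stay within the scatter. From the compounds shown here alone, it is equally open whether the number would hold if a carboxylic acid stood in place of the whole carbamoyl group, which would show whether the amide itself matters in this whole-animal test.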